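Ring contraction on the thiocarbonyl carbon: compound 1 to compound 4

A few compounds are considered here, and "the series" means these few. Any claim that something is new, unique, unknown or untested is made for them only; others in the source may bear on it.

Compound 1 `Nc1ccccc1NC(=O)c1ccc(CSC(=S)N2CCCc3ccccc32)cc1` is the reference point of the series. Going by the values given here, in a functional assay on MGC-803 cells (Homo sapiens) for antiproliferative activity, read by CCK-8 assay, with a stated time of 72 h, tested at 8 uM (a lower number here means a weaker effect, a higher number a stronger effect of the compound at the concentration tested), compound 1 gives 87.5%, the highest of the three numbers so far. Compound 3 `Nc1ccccc1NC(=O)c1ccc(CSC(=S)N2CCN(c3cccnc3)CC2)cc1` gives 76.9% in this assay, beyond the scatter below compound 1 but nearest to it. Compound 2 `COc1ccc(N2CCN(C(=S)SCc3ccc(C(=O)Nc4ccccc4N)cc3)CC2)cc1` gives 22.9% in this assay, the furthest from compound 1. Among the compounds with values here, the only one-place step among the measured compounds is a number 54 percentage points higher from compound 2 to compound 3 (beyond the scatter), a large step, but it concerns the aryl group on the amine nitrogen of a ring and does not touch the ring attached to the thiocarbonyl carbon.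

Compound 4 `Nc1ccccc1NC(=O)c1ccc(CSC(=S)N2CCc3ccccc32)cc1` differs from compound 1 in one place: 2,3-dihydro-1H-indol-1-yl in place of 1,2,3,4-tetrahydroquinolin-1-yl on a thiocarbonyl carbon. Within the data shown here, no measured pair alters this ring, so the step from compound 2 to compound 3 bears on it only in showing that the group on the thiocarbonyl carbon can move the read-out widely; it gives no direction for a change of one ring member with no donor or acceptor added or lost. The expectation is therefore a step within the scatter, a number 7.5 percentage points lower from compound 1 to compound 4 (within the scatter), with a slight downward lean. Compound 4 is expected to give 80% in this assay, in a range from 60% to 93%.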

Compound 4, a percentage reported as inhibition, at one concentration (the size of the read-out at that concentration, not a potency): 87%
Compound 4: the middle estimate sits 7 percentage points below what was measured; the range from low to high includes it.
By their numbers in this assay, from the lowest: compound 2; then compound 3; then compounds 4 and 1 (each within the scatter of the next).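

Within this assay, the one-place step that alters the ring on the thiocarbonyl carbon itself reads as a number 0.5 percentage points lower from compound 1 to compound 4 (within the scatter) and so does not separate 2,3-dihydro-1H-indol-1-yl from 1,2,3,4-tetrahydroquinolin-1-yl at the single concentration tested. Going by these compounds alone, this position therefore accepts the five-membered non-aromatic ring in place of the six-membered one with no readable change, whereas the earlier step of a number 54 percentage points higher from compound 2 to compound 3 (beyond the scatter) showed only that a change in the aryl group on the amine nitrogen of a different ring can move the read-out widely. Nothing at hand gives a reason for either outcome.

From the compounds shown here alone, a read-out at one concentration cannot show whether compound 1 and compound 4 differ in potency, so that comparison remains open, as does the effect of a larger ring such as a seven-membered benzazepine on the same thiocarbonyl carbon. Also open, going by these compounds, is whether the fused aromatic ring is needed at all, which a simple piperidine or an open-chain dimethylamino group would address, and how a fluorine or methoxy substituent on that aromatic ring would alter the read-out.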